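From phenyl to 4-(trifluoromethyl)phenyl on a shared core

A few compounds are considered here, and "the series" means these few. Any claim that something is new, unique, unknown or untested is made for them only; others in the source may bear on it.

Of the compounds shown here, three have been tested in an ADME assay on HepG2 cells (Homo sapiens) for cytotoxicity, read by CellTiter-Glo, with a stated time of 72 h; on this read-out lower numbers stand for an effect already at smaller amounts and higher numbers for an effect only at larger amounts of compound. Compound 1 `CC(=O)O[C@@H]1/C=C/C(C)(C)CC2=C(C)C(=O)[C@]3(C[C@@H](C)C=C3/C=C\1C)O2` gives 26000 nM, compound 2 `COc1ccc(/C2=C\C(=O)/C(C)=C\C3=C[C@H](C)C[C@@]34OC(=C(C)C4=O)CC2(C)C)cc1` gives 26000 nM, and compound 3 `CC1=C2CC(C)(C)/C(c3ccccc3)=C/C(=O)/C(C)=C\C3=C[C@H](C)C[C@]3(O2)C1=O` gives 26000 nM. Compound 3 therefore stands level with the other two, and the three values cannot be told apart.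

Compound 4 `CC1=C2CC(C)(C)/C(c3ccc(C(F)(F)F)cc3)=C/C(=O)/C(C)=C\C3=C[C@H](C)C[C@]3(O2)C1=O` differs from compound 3 at a single place: trifluoromethyl in place of hydrogen on an aromatic carbon. It has trifluoromethyl in place of hydrogen on an aromatic carbon, para to a large group, which turns phenyl into 4-(trifluoromethyl)phenyl.

Within the data shown here, only one measured step bears on this change, the one with hydrogen in place of methoxy on an aromatic carbon: no change at the digits printed from compound 2 to compound 3 (within the scatter). Among the measured compounds shown here, that step involves a different group, and no compound tested so far carries trifluoromethyl, so the evidence is thin. Even so, the one substituent swap on the aromatic ring left this assay unmoved, so no step beyond the scatter is expected here. The range is left wider towards lower numbers, as the data cannot exclude a move that way. The expected step is a 1.2-fold lower number from compound 3 to compound 4 (0.07 log units; within the scatter). Compound 4 is estimated at 22000 nM, with an expected range of 9000 nM to 32000 nM.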

Compound 4, half-maximal effective concentration: 26000 nM
Compound 4: middle estimate off by 1.2-fold (0.07 log units), on the low side; measured number inside the range.
By their numbers in this assay, from the lowest: compounds 1, 2, 3 and 4 (each within the scatter of the next).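

In this assay the change on an aromatic carbon para to a large group, from phenyl to 4-(trifluoromethyl)phenyl, leaves the reading where it was (no change at the digits printed from compound 3 to compound 4 (within the scatter)). The earlier compounds had shown this only for hydrogen in place of methoxy; this position now also accepts trifluoromethyl, a group of 4 heavy atoms, with no step beyond the scatter. The comparison between the two substituted rings reads the same (no change at the digits printed from compound 2 to compound 4 (within the scatter)), so hydrogen, methoxy and trifluoromethyl at this place cannot be told apart on this read-out, and no available measurement offers an explanation for that.

From the compounds shown here alone, whether an amine, a carboxylic acid or a longer chain such as n-butyl on the same aromatic carbon would also leave the number unmoved remains open. Also open is whether trifluoromethyl or methoxy placed on another carbon of the aromatic ring would give the same reading, as every substituted ring shown carries its group at this one position.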